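The source may hold more compounds than are shown below. What is called first, only, known or untested is meant among the compounds shown, and "the series" means these compounds.

Compound 1 `O=C(N[C@H]1CN(S(=O)(=O)c2ccccc2)C[C@@H]1C(=O)N1C[C@H]2CCNC[C@H]21)c1cc(-c2ccccc2Cl)on1`, compound 2 `O=C(N[C@H]1CN(S(=O)(=O)c2ccccc2)C[C@@H]1C(=O)NC[C@@H]1CCCN1)c1cc(-c2ccccc2Cl)on1` and compound 3 `CN(C(=O)[C@H]1CN(S(=O)(=O)c2ccccc2)C[C@@H]1NC(=O)c1cc(-c2ccccc2Cl)on1)[C@H]1CCCNC1` share one core. Compound 3 stands below compound 2 by a number 14 percentage points lower from compound 2 to compound 3 (beyond the scatter) in a functional assay on HEK293 cells for agonist activity at growth hormone secretagogue receptor type 1 (Homo sapiens), read by HTRF and inositol phosphate accumulation, with a stated time of 90 min, in the presence of a further agent that is not named here (a lower number here means a smaller maximal response, a higher number a larger maximal response), while the other gap around compound 3 stays within the scatter: a number 10 percentage points lower from compound 1 to compound 3 (within the scatter). In this assay compound 1 gives 98%, compound 2 gives 102% and compound 3 gives 88%. Compound 4 `O=CN1CCC[C@H](NC(=O)[C@H]2CN(S(=O)(=O)c3ccccc3)C[C@@H]2NC(=O)c2cc(-c3ccccc3Cl)on2)C1` differs from compound 3 at the same carbonyl carbon where all three measured compounds differ from one another: a group of 9 heavy atoms (6 carbon, 2 nitrogen, 1 oxygen; one six-membered non-aromatic ring with 1 hetero atom) in place of a group of 8 heavy atoms (6 carbon, 2 nitrogen; one six-membered non-aromatic ring with 1 hetero atom), on a carbonyl carbon. The steps measured at that place, a number 4 percentage points higher from compound 1 to compound 2 (within the scatter) and a number 10 percentage points lower from compound 1 to compound 3 (within the scatter), fall within the scatter, and a number 14 percentage points lower from compound 2 to compound 3 (beyond the scatter) is modest. A small step, or none beyond the scatter, is therefore expected in this assay. Compound 4 is estimated at 90%, between 75% and 105%. This estimate means an expected step of a number 2 percentage points higher from compound 3 to compound 4 (within the scatter).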

Compound 4, largest response reached (Emax), in percent of the reference or control that the assay uses: 90%
The estimate for compound 4 equals the measured number at the digits printed; low and high end bracket the measured number.
By their numbers in this assay, from the lowest: compounds 3, 4, 1 and 2 (each within the scatter of the next, the first and the last beyond it).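

At this carbonyl carbon, the group of 9 heavy atoms, with its oxygen and its double bond outside aromatic rings, leaves the maximal response in this assay in place, with a number 2 percentage points higher from compound 3 to compound 4 (within the scatter) as the step. Compound 4 also stays close to the core of compound 1, with a number 8 percentage points lower from compound 1 to compound 4 (within the scatter) as the step, while a number 12 percentage points lower from compound 2 to compound 4 (beyond the scatter) gives a modest gap like that seen for compound 3. On these data alone, whether a carboxylic acid or a longer chain at this carbonyl carbon would keep the response remains open. Nothing given here explains these results.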